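The source may hold more compounds than are shown below. What is called first, only, known or untested is meant among the compounds shown, and "the series" means these compounds.

Measured so far:
- compound 1, `C=C1C(=O)OC(C)CC1c1ccc([N+](=O)[O-])cc1`: 1200 nM
- compound 2, `C=C1C(=O)OC(C)CC1c1ccccc1OC`: 2100 nM
- compound 3, `C=C1C(=O)O[C@H](C)[C@@H]1c1ccc([N+](=O)[O-])cc1`: 1900 nM

In a functional assay on L1210 cells (Mus musculus) for cytotoxicity, read by MTT assay, with a stated time of 48 h (a higher number here means a weaker inhibitor, a lower number a stronger inhibitor), compound 3 gives 1900 nM, the second highest of the three numbers. Compound 2 gives 2100 nM, and compound 1 gives 1200 nM; both of these lie within the scatter of compound 3, so the three compounds cannot be separated on the numbers shown. Compound 4, `C=C1C(=O)O[C@H](C)[C@@H]1c1ccc(C)cc1`, has not yet been measured in this assay. It differs from compound 3 in one place: methyl in place of nitro on an aromatic carbon. Within the data shown here, no step between two measured compounds covers this exchange, so there is no measured precedent for it here. Among the measured compounds shown here, since the nitro and methoxy compounds measured so far give numbers within the scatter of each other, a small step is expected for compound 4, of no set direction and not clearly beyond the scatter. The estimated step from compound 3 to compound 4 is a 1.3-fold higher number from compound 3 to compound 4 (0.12 log units; within the scatter). Compound 4 is therefore expected to give about 2500 nM in this assay, within a range of 900 nM to 7000 nM.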

Compound 4, half-maximal inhibitory concentration: 5500 nM
Estimate against measurement, compound 4: 2.2-fold (0.34 log units) below, and the stated range covers the measured number.
By their numbers in this assay, from the lowest: compounds 1, 3 and 2 (each within the scatter of the next); then compound 4.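

Exchanging nitro for methyl on this aromatic carbon produces the first difference in the series that stands clear of the scatter: in this assay it gives a 2.9-fold higher number from compound 3 to compound 4 (0.46 log units; beyond the scatter). The earlier compounds shown here could not be separated from one another, whereas this pair shows that the group at this position can shift the number, although the step is modest and rests on a single exchange. Nothing available here accounts for the rise.

Among these compounds, the single pair leaves open whether the higher number goes with the departure of nitro or with the arrival of methyl, and whether the same exchange would give a similar step on the core of compound 1. An amine, a carboxylic acid or a longer chain on this aromatic carbon remains unaddressed by the compounds shown.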